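Hydroxymethyl in place of phenyl: working notes

The compounds below may be only part of what the source reports. "The series", "measured", "known", "first", "only" and "open" are said of these compounds alone.

Within the data shown here, in a functional assay on the whole organism with Rattus norvegicus as the target (a higher number here means that more compound is needed for the effect, a lower number that less compound is needed), compound 2 `CCOCCOC(=O)C(=O)Nc1nc(-c2cc(-c3ccccc3)on2)cs1` gives 13 mg/kg, the only actual number so far. Compound 1 `CCOCCOC(=O)C(=O)Nc1nc(-c2cc(Cl)no2)cs1`, which has no phenyl, gives > 30 mg/kg, and this value is a limit of the assay rather than a number.

Compound 3 `CCOCCOC(=O)C(=O)Nc1nc(-c2cc(CO)on2)cs1` carries hydroxymethyl in place of phenyl on an aromatic carbon. The change sits on the five-membered aromatic ring with 1 nitrogen and 1 oxygen, next to the ring oxygen.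

Among the measured compounds shown here, no measured pair isolates this change, so the expectation is tentative. It rests only on the two compounds above. A modest step towards a higher dose in this assay is expected, estimated as a 2.3-fold higher number from compound 2 to compound 3 (0.36 log units; beyond the scatter). A result reported only as a limit would not be surprising. For compound 3 the estimated dose is 30 mg/kg, with an expected range of 12 mg/kg to 75 mg/kg.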

Compound 3, dose for half-maximal effect: 14 mg/kg
Estimate against measurement, compound 3: 2.1-fold (0.33 log units) above; the measured number falls inside the stated range.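

In this assay, hydroxymethyl in place of phenyl on this aromatic carbon gives a 1.1-fold higher number from compound 2 to compound 3 (0.03 log units; within the scatter), so on these two compounds the six-membered aromatic ring is not required at this position for a dose in this range. The exchange of 3-chloro-1,2-oxazol-5-yl for 5-(hydroxymethyl)-1,2-oxazol-3-yl gives an at least 2.1-fold lower number from compound 1 to compound 3 (0.33 log units; beyond the scatter), a step that can be read only as a bound. Compound 1 gives > 30 mg/kg, which is a limit of the assay and not a number: the limit of > 30 mg/kg in this assay, at which 1 of the 3 values shown sits.

From the compounds shown here alone, whether the hydroxyl itself matters stays open, since methyl, methoxymethyl, aminomethyl or a carboxylic acid on the same carbon would each test a different part of hydroxymethyl. A longer chain such as hydroxyethyl would show how much room this position allows.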